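A few compounds are considered here, and "the series" means these few. Any claim that something is new, unique, unknown or untested is made for them only; others in the source may bear on it.

In an ADME assay on microsomes (Rattus norvegicus) for metabolic stability (a lower number here means that the compound disappears faster, a higher number that the compound lasts longer), compound 1 `CCC(=O)N1CCC(C(=O)N2N=CCC2c2ccccc2)CC1` gives 1.07 h. Compound 2 `O=C(c1cn[nH]c1)N1CCC(C(=O)N2N=CCC2c2ccccc2)CC1` stands at > 2.75 h, which is a limit of the assay and not a number. Compound 3 `O=C(c1c[nH]nn1)N1CCC(C(=O)N2N=CCC2c2ccccc2)CC1` differs from it in one place: 1H-1,2,3-triazol-4-yl in place of 1H-pyrazol-4-yl on a carbonyl carbon. Among the compounds with values here, only one measured step bears on this change, an at least 2.5-fold higher number from compound 1 to compound 2 (0.40 log units; beyond the scatter). That step replaced ethyl, not one five-membered aromatic ring with another, so it gives no size for this exchange. No shift beyond the scatter is therefore expected in this assay, in either direction, and the estimate is a step that the limit leaves unreadable from compound 2 to compound 3. The half-life expected for compound 3 is 3 h, with an estimated range of 1.5 h to 6 h.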

Compound 3, half-life: > 2.75 h
Compound 3: a limit, no number; the forecaster's own chance of this, stated with the estimate: 50%; the middle value lies beyond the limit too.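

In this assay, 1H-1,2,3-triazol-4-yl in place of ethyl on the carbonyl carbon gives an at least 2.5-fold higher number from compound 1 to compound 3 (0.40 log units; beyond the scatter). A second five-membered aromatic ring thus moves the number in the same direction as 1H-pyrazol-4-yl did, now with one more ring nitrogen. Compound 2 and compound 3 both stand at a limit of the assay, and the step between them cannot be read because of that shared limit: the limit of > 2.75 h in this assay, at which 2 of the 3 values shown sit.

As far as these compounds go, how far either ring lies past the limit stays open. Also open, from the compounds shown here alone, is whether an amine or a longer alkyl chain on the same carbonyl carbon would move the half-life as these two rings do.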